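The source may report more compounds than this note shows. Statements on the series, on what has been measured and on what is new or still open speak of the compounds shown alone.

Measured so far in a functional assay on HEK293 cells (Homo sapiens) for cytotoxicity; a lower number here means that less compound is tolerated, a higher number that more compound is tolerated:
- Compound 1 `COc1ccc([C@H]2CC(=O)N(c3cccc(C(F)(F)F)c3)C2)cc1OC1CCCC1` gives > 10000 nM
- Compound 2 `COc1ccc([C@H]2CC(=O)N(c3cccc(NS(=O)(=O)c4cccc(F)c4)c3)C2)cc1OC1CCCC1` gives > 10000 nM
- Compound 3 `COc1ccc([C@H]2CC(=O)N(c3cccc(NS(=O)(=O)c4c(F)cccc4F)c3)C2)cc1OC1CCCC1` gives > 10000 nM

Each of these is a limit of the assay, not a number. Compound 3 therefore stands only at its limit (> 10000 nM). Compound 4 `COc1ccc([C@H]2CC(=O)N(c3cccc(NS(=O)(=O)c4ccccc4C)c3)C2)cc1OC1CCCC1` carries 2-methylphenyl in place of 2,6-difluorophenyl on a sulfonyl sulfur. The closest measured change, at that same sulfur, is a step that the two limits leave unreadable from compound 2 to compound 3. The two changes from trifluoromethyl, a step that the two limits leave unreadable from compound 1 to compound 2 and a step that the two limits leave unreadable from compound 1 to compound 3, give no readable size either. Compound 1, compound 2 and compound 3 all share one ceiling (the limit of > 10000 nM in this assay, at which 3 of the 3 values shown sit), so no step beyond the scatter is expected in this assay. The estimated step is a step that the limit leaves unreadable from compound 3 to compound 4. The expected value for compound 4 is 20000 nM, estimated to lie between 9000 nM and 40000 nM.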

Compound 4, half-maximal cytotoxic concentration: > 10000 nM
Compound 4 gave a limit, no number; the forecaster's own chance of this, stated with the estimate: 90%; the middle value does not contradict the limit.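

For the compounds shown here, compound 4 is also a limit in this assay, so no step among compound 1, compound 2, compound 3 and compound 4 can be read: the limit of > 10000 nM in this assay, at which 4 of the 4 values shown sit. The compounds shown leave open how far apart they truly lie in this assay.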